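Alkyl arm in place of the sulfonamide on the shared core

The source may report more compounds than this note shows. Statements on the series, on what has been measured and on what is new or still open speak of the compounds shown alone.

Compound 1 `O=C1O[C@H]([C@@H](O)Cn2cc(CNS(=O)(=O)c3ccc(F)cc3)nn2)C(OCc2ccccc2)=C1OCc1ccccc1` carries a ((4-fluorophenyl)sulfonyl)amino group on a saturated chain carbon bound to an aromatic carbon. In a functional assay on HepG2 cells (Homo sapiens) for antiproliferative activity, read by MTT assay, with a stated time of 72 h (on this read-out lower numbers stand for stronger inhibition and higher numbers for weaker inhibition), compound 1 gives 18300 nM, the lowest of the two numbers in hand. Compound 2 `O=C1O[C@H]([C@@H](O)Cn2cc(-c3cc(C(F)(F)F)cc(C(F)(F)F)c3)nn2)C(OCc2ccccc2)=C1OCc1ccccc1` gives 33800 nM in this assay, and its gap from compound 1 stays within the scatter, so no order between the two can be read. Compound 3 `CC(C)(C)OC(=O)N1CCN(C(=S)SCc2cn(C[C@H](O)[C@H]3OC(=O)C(OCc4ccccc4)=C3OCc3ccccc3)nn2)CC1` reaches only a limit of this assay, > 100000 nM. That limit is the limit of > 100000 nM in this assay, at which 1 of the 3 values shown sits. Going by the values given here, no step between measured compounds that differ in one place is available in this set.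

Compound 4 `CCCCc1cn(C[C@H](O)[C@H]2OC(=O)C(OCc3ccccc3)=C2OCc2ccccc2)nn1` is the next point. Its difference from compound 1 is propyl in place of ((4-fluorophenyl)sulfonyl)amino on a saturated chain carbon bound to an aromatic carbon. A plain propyl chain replaces the whole arylsulfonamide arm, and nothing measured here shows what such a cut does. The step of a 2.2-fold higher number from compound 1 to compound 4 (0.34 log units; beyond the scatter) is expected to run toward weaker inhibition, of a size at the edge of the scatter. Compound 4 is therefore estimated at 40000 nM in this assay, within a range of 12000 nM to 150000 nM.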

Compound 4, half-maximal inhibitory concentration: 32800 nM
The estimate for compound 4 lay 1.2-fold (0.09 log units) above the measured number; low and high end bracket the measured number.
By their numbers in this assay, from the lowest: compounds 1, 4 and 2 (each within the scatter of the next). At a limit, above all of these: compound 3.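

In this assay the exchange of ((4-fluorophenyl)sulfonyl)amino for propyl gives a 1.8-fold higher number from compound 1 to compound 4 (0.25 log units; within the scatter), although the group that leaves has 11 heavy atoms, an aromatic ring, a hydrogen-bond donor and hydrogen-bond acceptors, and propyl has 3 heavy atoms and none of these features. At this place, on a saturated chain carbon bound to an aromatic carbon, the read-out therefore does not separate the arylsulfonamide arm from a plain alkyl chain. Nothing in hand bears on why the two compounds cannot be told apart.

As far as these compounds go, whether a primary amine or a carboxylic acid at this place would give a number beyond the scatter from compound 1 remains open. So does the effect of a longer chain, such as octyl, in place of propyl.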